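The source may report more compounds than this note shows. Statements on the series, on what has been measured and on what is new or still open speak of the compounds shown alone.

Of the compounds shown here, three have been measured in a functional assay on SGC-7901 cells (Homo sapiens) for antiproliferative activity, read by MTT assay, with a stated time of 24 h; a higher number here means a weaker inhibitor, a lower number a stronger inhibitor. Compound 1 (`O=C(NNc1ccccc1F)c1ccc(NS(=O)(=O)c2cnc(O)nc2O)cc1`) gives 16000 nM in this assay. Compound 2 (`O=C(NNc1ccc(F)cc1)c1ccc(NS(=O)(=O)c2cnc(O)nc2O)cc1`) gives > 20000 nM, which is a limit of the assay and not a number. Compound 3 (`Cc1ccccc1NNC(=O)c1cccc(NS(=O)(=O)c2cnc(O)nc2O)c1`) gives > 20000 nM, which is also a limit and not a number. Compound 3 therefore has no number of its own and stands at the limit of > 20000 nM in this assay, at which 2 of the 3 values shown sit.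

Compound 4 (`O=C(NNc1ccc(F)cc1)c1cccc(NS(=O)(=O)c2cnc(O)nc2O)c1`) has not yet been measured. Its difference from compound 3 is 4-fluorophenyl in place of 2-methylphenyl on an amine nitrogen, with 4-fluorophenyl in place of 2-methylphenyl on an amine nitrogen.

Within the data shown here, only one measured step bears on this change: an at least 1.2-fold higher number from compound 1 to compound 2 (0.09 log units; that floor lies within the scatter). That step brings in the same 4-fluorophenyl at the same kind of place, but a different group leaves, so it offers indirect guidance only. Its floor lies within the scatter, so no shift beyond the scatter is expected in either direction. A report of compound 4 as a limit is considered the likeliest outcome.

The expected change is a step that the limit leaves unreadable from compound 3 to compound 4. For compound 4 the estimated value is 22000 nM, with an expected range from 11000 nM to 45000 nM.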

Compound 4, half-maximal inhibitory concentration: > 20000 nM
Compound 4 gave a limit, no number; the forecaster's own chance of this, stated with the estimate: 65%; the middle value does not contradict the limit.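

Compound 3 and compound 4 both give a limit rather than a number in this assay, so no step can be read between them: the limit of > 20000 nM in this assay, at which 3 of the 4 values shown sit.

The compounds shown leave open whether 4-fluorophenyl in place of 2-methylphenyl on an amine nitrogen changes the result in this assay at all, and in which direction.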